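The source may report more compounds than this note shows. Statements on the series, on what has been measured and on what is new or still open speak of the compounds shown alone.

Measured so far:
- compound 1 `O=[N+]([O-])c1ccc(-c2nnc(SCCCN3CCN(c4nc5ccccc5o4)CC3)o2)cc1`: 46900 nM
- compound 2 `Cc1ccc(-c2nnc(SCCCN3CCN(c4nc5ccccc5o4)CC3)o2)cc1`: 100000 nM
- compound 3 `O=[N+]([O-])c1ccc(-c2nnc(SCCCN3CCN(c4nc5ccccc5s4)CC3)o2)cc1`: 46500 nM

All three were run in a functional assay on A-431 cells (Homo sapiens) for inhibition, read by MTT assay, with a stated time of 72 h; on this read-out higher numbers stand for weaker inhibition and lower numbers for stronger inhibition. Compound 1 gives 46900 nM in this assay, compound 2 gives 100000 nM, and compound 3 gives 46500 nM.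

The two cores differ as follows: 1,3-benzothiazol-2-yl in place of 1,3-benzoxazol-2-yl on an amine nitrogen in a ring. On this assay that change is a 1.0-fold lower number from compound 1 to compound 3 (0.00 log units; within the scatter), so compound 1 and compound 3 cannot be told apart here.

The change that is of interest occurs twice among these compounds. Between compound 1 and compound 2 it reads (methyl in place of nitro on an aromatic carbon), and the step it made was a 2.1-fold higher number from compound 1 to compound 2 (0.33 log units; beyond the scatter). The unmeasured compound 4 `Cc1ccc(-c2nnc(SCCCN3CCN(c4nc5ccccc5s4)CC3)o2)cc1` stands to compound 3 as compound 2 stands to compound 1: methyl in place of nitro on an aromatic carbon. The place description is the same word for word in both cases, so the same change is made on the two cores.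

Among the measured compounds shown here, because a 1.0-fold lower number from compound 1 to compound 3 (0.00 log units; within the scatter) shows the two cores to behave alike, and because a 2.1-fold higher number from compound 1 to compound 2 (0.33 log units; beyond the scatter) is the only reading of this change, compound 4 is expected to follow the earlier step, giving an estimated 2.0-fold higher number from compound 3 to compound 4 (0.31 log units; beyond the scatter). That rests on a single pair, so the expectation is loose. For compound 4 the estimated value is 95000 nM, expected to lie between 45000 nM and 200000 nM.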

Compound 4, half-maximal inhibitory concentration: 61600 nM
Estimate against measurement, compound 4: 1.5-fold (0.19 log units) above; measured number inside the range.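

In this assay, methyl in place of nitro on the core carrying 1,3-benzothiazol-2-yl gives a 1.3-fold higher number from compound 3 to compound 4 (0.12 log units; within the scatter), and this step does not differ from the one on the core carrying 1,3-benzoxazol-2-yl: the same change on two cores in this assay, a 2.1-fold higher number (0.33 log units; beyond the scatter) from compound 1 to compound 2 and a 1.3-fold higher number (0.12 log units; within the scatter) from compound 3 to compound 4, 1.6-fold (0.21 log units) apart, within the scatter of two such steps. Read the other way round the square, 1,3-benzothiazol-2-yl in place of 1,3-benzoxazol-2-yl gives a 1.6-fold lower number from compound 2 to compound 4 (0.21 log units; within the scatter) on the methyl-bearing compounds, and this exchange also reads the same with either aromatic group in place: the same change on two cores in this assay, a 1.0-fold lower number (0.00 log units; within the scatter) from compound 1 to compound 3 and a 1.6-fold lower number (0.21 log units; within the scatter) from compound 2 to compound 4, 1.6-fold (0.21 log units) apart, within the scatter of two such steps. The four compounds therefore fit a change that carries from one core to the other, but this rests on one pair per core, the step on the second core cannot be told from scatter, and nothing here shows that methyl and nitro differ on that core or that the agreement extends beyond these compounds.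

Still open, from the compounds shown here alone, is whether other groups in place of nitro on the 4-nitrophenyl ring, such as an amine, a carboxylic acid or a halogen, would also read alike on the two cores. The compounds shown also leave open whether a shorter or longer chain on the sulfur would keep the two cores interchangeable.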